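The compounds below may be only part of what the source reports. "The series", "measured", "known", "first", "only" and "open" are said of these compounds alone.

Measured in a functional assay on HEL cells (Homo sapiens) for inhibition, read by MTT assay, with a stated time of 48 h; on this read-out higher numbers stand for weaker inhibition and lower numbers for stronger inhibition:
Compound 1 `O=C(NO)c1ccc(Oc2no[n+]([O-])c2S(=O)(=O)c2ccccc2)cc1`: 920 nM
Compound 2 `COc1cc(C(=O)NO)ccc1Oc1no[n+]([O-])c1S(=O)(=O)c1ccccc1`: 5550 nM

Compound 1 has the lower of the two numbers, making it the stronger inhibitor so far. Compound 3 `O=C(/C=C/c1ccc(Oc2no[n+]([O-])c2S(=O)(=O)c2ccccc2)cc1)NO` alters it in one place: 2-(hydroxycarbamoyl)ethenyl in place of hydroxycarbamoyl on an aromatic carbon. Within the data shown here, the only measured step, a 6.0-fold higher number from compound 1 to compound 2 (0.78 log units; beyond the scatter), comes from a different change, methoxy in place of hydrogen on an aromatic carbon. It was modest and offers a rough size but no direction, so a modest step or none beyond the scatter is expected in this assay. For compound 3 the estimated value is 600 nM, with an expected range of 130 nM to 2800 nM. This estimate means an expected 1.5-fold lower number from compound 1 to compound 3 (0.19 log units; within the scatter).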

Compound 3, half-maximal inhibitory concentration: 2410 nM
Compound 3: the middle estimate sits 4.0-fold (0.60 log units) below what was measured, within the range that was stated.
By their numbers in this assay, from the lowest: compound 1; then compound 3; then compound 2.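

In this assay, putting 2-(hydroxycarbamoyl)ethenyl in place of hydroxycarbamoyl on this aromatic carbon gives a 2.6-fold higher number from compound 1 to compound 3 (0.42 log units; beyond the scatter), so inhibition weakens modestly. Among these compounds, this is the first sign that the position responds to a change in the group itself: adding the ethenyl part keeps the hydrogen-bond donor and acceptor counts the same but does not improve inhibition. Nothing available explains this loss.

Going by these compounds, it remains open how a longer chain ending in hydroxycarbamoyl would behave at this position. Also open, on these data alone, is whether a carboxylic acid could replace hydroxycarbamoyl.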